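The compounds below may be only part of what the source reports. "The series", "measured", "known", "first", "only" and "open" are said of these compounds alone.

Measured compounds:
compound 1, `O=C1NCCN1c1ccc(S(=O)(=O)Nc2ccc(F)c(F)c2)cc1`, 350 nM in a functional assay on HT-29 cells (Homo sapiens) for antiproliferative activity, read by sulforhodamine B assay, with a stated time of 48 h; on this read-out higher numbers stand for weaker inhibition and lower numbers for stronger inhibition
compound 2, `COc1ccccc1NS(=O)(=O)c1ccc(N2CCNC2=O)cc1`, 550 nM
compound 3, `O=C1NCCN1c1ccc(S(=O)(=O)Nc2ccc(I)cc2)cc1`, 650 nM

Compound 3 returns the highest of the three numbers, yet a 1.2-fold higher number from compound 2 to compound 3 (0.07 log units; within the scatter) and a 1.9-fold higher number from compound 1 to compound 3 (0.27 log units; within the scatter) are both within the scatter, so the three values sit together. Compound 4, `Cc1ccc(NS(=O)(=O)c2ccc(N3CCNC3=O)cc2)c(C)c1`, has not been measured. It differs from compound 3 by 2,4-dimethylphenyl in place of 4-iodophenyl on a sulfonamide nitrogen. Going by the values given here, the steps that bear on this change are those that also vary the group on the sulfonamide nitrogen: a 1.9-fold higher number from compound 1 to compound 3 (0.27 log units; within the scatter), a 1.2-fold higher number from compound 2 to compound 3 (0.07 log units; within the scatter) and a 1.6-fold higher number from compound 1 to compound 2 (0.20 log units; within the scatter), none of which left the scatter. No step beyond the scatter is therefore expected in this assay. Compound 4 is expected to give 550 nM, with a range from 250 nM to 1200 nM. That expectation corresponds to a 1.2-fold lower number from compound 3 to compound 4 (0.07 log units; within the scatter).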

Compound 4, half-maximal inhibitory concentration: 180 nM
Compound 4: the middle estimate sits 3.1-fold (0.49 log units) above what was measured; the measured number lies below the stated range.
By their numbers in this assay, from the lowest: compounds 4, 1, 2 and 3 (each within the scatter of the next, the first and the last beyond it).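

In this assay, going by these compounds alone, the group on the sulfonamide nitrogen now produces steps beyond the scatter, which no earlier pair showed: 2,4-dimethylphenyl gives (a 3.6-fold lower number from compound 3 to compound 4 (0.56 log units; beyond the scatter)) and (a 3.1-fold lower number from compound 2 to compound 4 (0.49 log units; beyond the scatter)). The same group does not separate from 3,4-difluorophenyl (a 1.9-fold lower number from compound 1 to compound 4 (0.29 log units; within the scatter)), so compound 1 and compound 4 sit together. Nothing measured here gives a reason for this pattern. The compounds shown leave open whether both methyl groups of 2,4-dimethylphenyl are needed, as neither methylphenyl isomer appears. They also leave open how an amine or a carboxylic acid on this ring would read.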